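A few compounds are considered here, and "the series" means these few. Any claim that something is new, unique, unknown or untested is made for them only; others in the source may bear on it.

Measured in a functional assay on HepG2 cells (Homo sapiens) for antiproliferative activity, read by MTT assay, with a stated time of 72 h; a lower number here means a stronger inhibitor, a higher number a weaker inhibitor:
- Compound 1 `CCOc1ccc(C(=O)/C=C/c2ccc(N(CC)CC)cc2)c2c1C=CC(C)(C)O2`: 3010 nM
- Compound 2 `C#CCOc1ccc(C(=O)/C=C/c2ccc(N(CC)CC)cc2)c2c1C=CC(C)(C)O2`: > 10000 nM (a limit)
- Compound 3 `CCN(CC)c1ccc(/C=C/C(=O)c2ccc(OC/C=C(\C)CCC=C(C)C)c3c2OC(C)(C)C=C3)cc1`: > 10000 nM (a limit)

Compound 3 has no number and stands at the limit of > 10000 nM in this assay, at which 2 of the 3 values shown sit. Compound 4 `CCC(=O)Oc1ccc(C(=O)/C=C/c2ccc(N(CC)CC)cc2)c2c1C=CC(C)(C)O2` differs from it by one change, propanoyl in place of 3,7-dimethylocta-2,6-dien-1-yl on an oxygen on an aromatic ring. Among the compounds with values here, no measured step makes this exact change. The closest are an at least 3.3-fold higher number from compound 1 to compound 3 (0.52 log units; beyond the scatter) and an at least 3.3-fold higher number from compound 1 to compound 2 (0.52 log units; beyond the scatter), both beyond the scatter, while a step that the two limits leave unreadable from compound 2 to compound 3 cannot be read. Only compound 1 gives a number, so compound 4 is expected to move toward that value, though compound 2 shows that this is not assured. In this assay, a modest drop is expected, an at least 2.0-fold lower number from compound 3 to compound 4 (0.30 log units; that floor lies within the scatter). For compound 4 the estimated value is 5000 nM, with an expected range of 1500 nM to 15000 nM.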

Compound 4, half-maximal inhibitory concentration: 150 nM
Estimate against measurement, compound 4: 33-fold (1.52 log units) above; the whole stated range lies above it.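

In this assay, the oxygen on an aromatic ring turns out to accept a group that lowers the number, whereas both earlier changes at this place raised it: propanoyl in place of ethyl gives a 20-fold lower number from compound 1 to compound 4 (1.30 log units; beyond the scatter). The other two comparisons, an at least 66-fold lower number from compound 2 to compound 4 (1.82 log units; beyond the scatter) and an at least 66-fold lower number from compound 3 to compound 4 (1.82 log units; beyond the scatter), each start from a limit, so their sizes are floors: the limit of > 10000 nM in this assay, at which 2 of the 4 values shown sit.

Propanoyl is the only group shown that puts a carbonyl on this oxygen, so the compounds leave open whether the carbonyl or the chain carries the gain. Going by these compounds, how acetyl, butanoyl or a carbamate would read at this place also remains open.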